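The compounds below may be only part of what the source reports. "The series", "measured", "known", "first", "only" and "open" are said of these compounds alone.

Three compounds of the series have been run in an assay on blood for inhibition of C-X-C chemokine receptor type 3 (Homo sapiens), with a stated time of 30 min; on this read-out lower numbers stand for stronger inhibition and higher numbers for weaker inhibition. Compound 1 `CC[C@@H]1CN(c2scnc2-c2nc3ccccc3[nH]2)CCN1C(=O)Cn1cnc2cccnc21` gives 851 nM, compound 2 `COc1ncc(-c2nc(C(F)(F)F)sc2N2CCN(C(=O)Cn3cnc4cccnc43)[C@H](C)C2)cn1` gives 158 nM, and compound 3 `COc1ncc(-c2nc(C(F)(F)F)sc2N2CCN(C(=O)Cn3nc(C)nc3C)[C@H](C)C2)cn1` gives 1040 nM, a number far from that of compound 2 and within the scatter of that of compound 1. The single step shown within this set, a 6.6-fold higher number from compound 2 to compound 3 (0.82 log units; beyond the scatter), concerns the group on the saturated chain carbon bound to the carbonyl carbon and leaves the rest of the structure untouched. Compound 4 `CCCc1ncc(-c2nc(C(F)(F)F)sc2N2CCN(C(=O)Cn3nc(C)nc3C)[C@H](C)C2)cn1` changes compound 3 elsewhere: propyl in place of methoxy on an aromatic carbon. Going by the values given here, no measured pair varies this part of the molecule, so the step has no precedent among the numbers in hand. The expected step of a 1.0-fold lower number from compound 3 to compound 4 (0.02 log units; within the scatter) is therefore one that stays within the scatter. Compound 4 is estimated at 1000 nM, with a range from 300 nM to 3500 nM.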

Compound 4, half-maximal inhibitory concentration: 367 nM
The estimate for compound 4 lay 2.7-fold (0.44 log units) above the measured number; the measured number falls inside the stated range.
By their numbers in this assay, from the lowest: compound 2; then compound 4; then compounds 1 and 3 (each within the scatter of the next).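

At the position between two ring nitrogen atoms, the number in this assay responds to substitution: propyl in place of methoxy gives a 2.8-fold lower number from compound 3 to compound 4 (0.45 log units; beyond the scatter) as the first step read at this site. The oxygen and its hydrogen-bond acceptor can therefore be lost here without a rise in the number. Nothing at hand explains the step.
On these data alone, it remains open whether the same change carries over to compound 2 with its different group on the chain carbon. Also open, as far as these compounds go, is how an ethyl group, a longer chain or an amine would read at this position.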